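The compounds below may be only part of what the source reports. "The series", "measured", "known", "first", "only" and "open" are said of these compounds alone.

In a functional assay on MDA-MB-231 cells (Homo sapiens) for antiproliferative activity, read by sulforhodamine B assay, with a stated time of 48 h (on this read-out higher numbers stand for weaker inhibition and lower numbers for stronger inhibition), compound 1 (`COc1ccc2nc(-c3ccc(N/C=C\C(=O)c4cc(OC)c(OC)c(OC)c4)cc3)sc2c1`) gives 19600 nM and compound 2 (`COc1ccc2nc(-c3ccc(N/C=C\C(=O)c4cc(OC)c(OC)c(OC)c4Br)c(C)c3)sc2c1`) gives 9400 nM as the lower of the two numbers, a gap beyond the usual scatter. Compound 3 (`COc1ccc2nc(-c3ccc(N/C=C\C(=O)c4cc(OC)c(OC)c(OC)c4Br)cc3)sc2c1`) carries hydrogen in place of methyl on an aromatic carbon and is otherwise the same as compound 2. Within the data shown here, no measured pair shows this change alone, so only a small step is expected in this assay towards a somewhat higher number, possibly no more than the scatter. The expected change is a 1.4-fold higher number from compound 2 to compound 3 (0.14 log units; within the scatter) on this estimate. For compound 3 the estimated value is 13000 nM (range 6000 nM to 26000 nM).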

Compound 3, half-maximal inhibitory concentration: 11100 nM
Estimate against measurement, compound 3: 1.2-fold (0.07 log units) above; the measured number falls inside the stated range.
By their numbers in this assay, from the lowest: compounds 2, 3 and 1 (each within the scatter of the next, the first and the last beyond it).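

In this assay the step of a 1.2-fold higher number from compound 2 to compound 3 (0.07 log units; within the scatter) comes with hydrogen in place of methyl on an aromatic carbon, so at this place methyl and hydrogen cannot be told apart. The step of a 1.8-fold lower number from compound 1 to compound 3 (0.25 log units; within the scatter) comes with bromo in place of hydrogen on an aromatic carbon, so this single change is not resolved either. No measurement at hand gives a reason for either step. Still open, going by these compounds, is whether an amine or a fluoro group at the methyl position would give a number beyond the scatter.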